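Phenyl Amide to Methoxyethyl Amide: Expected Gain in Solubility

The source may hold more compounds than are shown below. What is called first, only, known or untested is meant among the compounds shown, and "the series" means these compounds.

Compound 1 `O=C(Nc1ccccc1)c1cnc(NCc2c(F)ccc3c2CCO3)n2cnnc12` is the starting point. In a physicochemical assay for solubility, read by LC-MS, in phosphate buffer, with a stated time of 24 h, at pH 7.4 (on this read-out higher numbers stand for higher solubility and lower numbers for lower solubility), compound 1 gives < 1000 nM, which is a limit of the assay rather than a number; it sits at the lower limit (the limit of < 1000 nM in this assay, at which 1 of the 3 values shown sits). Compound 2 `Cc1nc(CN(C)C)ccc1-c1cnc(NCc2c(F)ccc3c2CCO3)c2cn[nH]c(=O)c12` gives > 1000000 nM in this assay, also a limit, at the upper edge (the limit of > 1000000 nM in this assay, at which 1 of the 3 values shown sits). Among the compounds with values here, compound 3 `Cc1ncccc1-c1cnc(NCc2c(F)ccc3c2CCO3)c2nn(CC#N)c(=O)n12` gives 4000 nM in this assay, the only plain number among the three. Compound 1 therefore stands at the low end of what has been seen so far, with compound 3 above it and compound 2 far above both.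

Compound 4 `COCCC(=O)Nc1cnc(NCc2c(F)ccc3c2CCO3)n2cnnc12` is not yet measured. It differs from compound 1 in one place: ((2-methoxyethyl)carbonyl)amino in place of phenylcarbamoyl on an aromatic carbon. Within the data shown here, no pair of measured compounds shares this change, so its size must be guessed. The step from the limit of compound 1 is expected to be upward and beyond the usual scatter in this assay. Compound 4 is estimated at 6000 nM, in a range from 1000 nM to 40000 nM. That estimate means a step of an at least 6.0-fold higher number from compound 1 to compound 4 (0.77 log units; beyond the scatter).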

Compound 4, solubility: 980000 nM
Estimate against measurement, compound 4: 160-fold (2.21 log units) below, outside the stated range (above it).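

Within the data shown here, on this aromatic carbon, ((2-methoxyethyl)carbonyl)amino in place of phenylcarbamoyl brings an at least 980-fold higher number from compound 1 to compound 4 (2.99 log units; beyond the scatter) in this assay, the first step in this set that changes one place only. Neither group carries a net charge, and the step comes with the loss of the six-membered aromatic ring of carbon only, as the entering group has no ring. The true size of the step stays unknown because compound 1 rests at a limit of the assay: the limit of < 1000 nM in this assay, at which 1 of the 4 values shown sits.

The compounds shown leave open which part of the change carries the step: the loss of the phenyl ring, the turned amide or the methoxy oxygen. A plain propyl chain, a cyclohexyl ring or a terminal amine on the same amide would be needed to tell these apart.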